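The source may report more compounds than this note shows. Statements on the series, on what has been measured and on what is new or still open speak of the compounds shown alone.

Measured compounds:
compound 1 `Cc1ccccc1Nc1nc(SCc2ccc(C(F)(F)F)cc2)nc2ccccc12`: 37500 nM
compound 2 `COc1ccc(Nc2nc(SCc3ccc(C(F)(F)F)cc3)nc3ccccc23)cc1`: 47200 nM

For the measured compounds named here, in a functional assay on MCF7 cells (Homo sapiens) for cytotoxicity, read by MTT assay, with a stated time of 72 h (a higher number here means a weaker inhibitor, a lower number a stronger inhibitor), compound 1 stands within the scatter of compound 2, the only other number: a 1.3-fold higher number from compound 1 to compound 2 (0.10 log units; within the scatter), for 4-methoxyphenyl in place of 2-methylphenyl on a nitrogen on an aromatic ring. Compound 3 `COc1cc(Nc2nc(SCc3ccc(C(F)(F)F)cc3)nc3ccccc23)cc(OC)c1` is not yet measured. It differs from compound 1 by 3,5-dimethoxyphenyl in place of 2-methylphenyl on a nitrogen on an aromatic ring. Going by the values given here, the one measured step that bears on this, a 1.3-fold higher number from compound 1 to compound 2 (0.10 log units; within the scatter), lies within the scatter, so no step beyond the scatter is expected in this assay. The expected step is a 1.2-fold higher number from compound 1 to compound 3 (0.08 log units; within the scatter). Compound 3 is estimated at 45000 nM, range 18000 nM to 110000 nM.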

Compound 3, half-maximal inhibitory concentration: 6990 nM
Beside the measured number, compound 3's estimate is 6.4-fold (0.81 log units) above it; the whole stated range lies above it.
By their numbers in this assay, from the lowest: compound 3; then compounds 1 and 2 (each within the scatter of the next).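

In this assay, the group on the nitrogen does shift the number: 3,5-dimethoxyphenyl gives a 5.4-fold lower number from compound 1 to compound 3 (0.73 log units; beyond the scatter) and a 6.8-fold lower number from compound 2 to compound 3 (0.83 log units; beyond the scatter), whereas the change from 2-methylphenyl to 4-methoxyphenyl stayed within the scatter. A methoxy group alone does not go with the lower number, as compound 2 carries one and stays within the scatter of compound 1. Nothing available explains this step.

As far as these compounds go, whether the step needs both methoxy groups remains open. Also open, from the compounds shown here alone, is whether an amine or a carboxylic acid in their place would give a step of similar size.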